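Capping the Amine: From Aminoethyl to Acetyl

This account rests on a few compounds, and the source may have more. Where it says the series, first, only, none or still open, it means among the compounds named here.

Among three compounds measured in an assay on HEK293 cells for displacement of a labelled ligand from Melanocortin receptor 4 (Homo sapiens) (a lower number here means a stronger inhibitor, a higher number a weaker inhibitor), compound 3 `CCC(C)[C@H](NCCN)c1cc(C(F)(F)F)ccc1N1CCN(C(=O)CCc2ccc(Cl)cc2Cl)CC1` gives 56 nM, the lowest number of the set. Compound 1 `CCCCC(N)c1cc(C(F)(F)F)ccc1N1CCN(C(=O)CCc2ccc(Cl)cc2Cl)CC1` gives 190 nM and compound 2 `CCC(C)C(N)c1cc(C(F)(F)F)ccc1N1CCN(C(=O)CCc2ccc(Cl)cc2Cl)CC1` gives 160 nM in this assay; the step of a 1.2-fold lower number from compound 1 to compound 2 (0.07 log units; within the scatter) lies within the scatter. The steps of a 3.4-fold lower number from compound 1 to compound 3 (0.53 log units; beyond the scatter) and a 2.9-fold lower number from compound 2 to compound 3 (0.46 log units; beyond the scatter) are modest but beyond the scatter. Compound 4 `CCC(C)[C@H](NC(C)=O)c1cc(C(F)(F)F)ccc1N1CCN(C(=O)CCc2ccc(Cl)cc2Cl)CC1` differs from compound 3 by acetyl in place of 2-aminoethyl on an amine nitrogen. For the measured compounds named here, the gain seen in the steps to compound 3 came with the 2-aminoethyl group, which compound 4 no longer carries, and no measured step covers an acetyl at this amine nitrogen. A loss is therefore expected for compound 4, roughly a 7.1-fold higher number from compound 3 to compound 4 (0.85 log units; beyond the scatter), with an estimated 400 nM between 120 nM and 1500 nM in this assay.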

Compound 4, inhibition constant: 360 nM
The estimate for compound 4 lay 1.1-fold (0.05 log units) above the measured number, and the stated range covers the measured number.
By their numbers in this assay, from the lowest: compound 3; then compounds 2, 1 and 4 (each within the scatter of the next, the first and the last beyond it).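

In this assay, this amine nitrogen proves sensitive in both directions: acetyl in place of 2-aminoethyl gives a 6.4-fold higher number from compound 3 to compound 4 (0.81 log units; beyond the scatter), removing the earlier gain. The acetyl cap also leaves the number above that of the uncapped amine, with a 2.3-fold higher number from compound 2 to compound 4 (0.35 log units; beyond the scatter), while a 1.9-fold higher number from compound 1 to compound 4 (0.28 log units; within the scatter) stays within the scatter. Nothing available here bears on the cause of these changes. The compounds shown leave open whether a 3-aminopropyl chain or a 2-hydroxyethyl group on this nitrogen would match 2-aminoethyl. They also leave open whether a simple ethyl group would behave more like acetyl.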